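The source may report more compounds than this note shows. Statements on the series, on what has been measured and on what is new or still open speak of the compounds shown alone.

Measured so far in a functional assay on MCF7 cells (Homo sapiens) for inhibition; a lower number here means a stronger inhibitor, a higher number a weaker inhibitor:
compound 1, `CC/C(=C(/c1ccc(/C=C/C(=O)O)cc1)c1cc2ccccc2[nH]1)c1cccc(C)c1`: 140 nM
compound 2, `CC/C(=C(/c1ccc(/C=C/C(=O)O)cc1)c1cc2ccccc2[nH]1)c1ccc(OC)cc1`: 61 nM

Compound 2 gives the lowest number of the two; its nearest neighbour is compound 1, and the step of a 2.3-fold lower number from compound 1 to compound 2 (0.36 log units; beyond the scatter) lies beyond the scatter, so compound 2 stands apart as the stronger of the pair. Compound 3, `CC/C(=C(/c1ccc(/C=C/C(=O)O)cc1)c1cc2ccccc2[nH]1)c1ccc(Cl)cc1Cl`, is not yet measured. It differs from compound 2 in one place: 2,4-dichlorophenyl in place of 4-methoxyphenyl on a double-bonded chain carbon bound to a double-bonded chain carbon and a saturated chain carbon. Going by the values given here, the single measured step that bears on this position, a 2.3-fold lower number from compound 1 to compound 2 (0.36 log units; beyond the scatter), was modest and went with the arrival of the 4-methoxyphenyl that compound 3 now gives up; the one hydrogen-bond acceptor is lost and two chlorines enter. Among the compounds with values here, no measured pair shows what a 2,4-dichlorophenyl does on this carbon, so the direction rests on little. Giving up the group that carried the gain seen in a 2.3-fold lower number from compound 1 to compound 2 (0.36 log units; beyond the scatter) points to a number somewhat above that of compound 2, though probably not by much more than the scatter. Compound 3 is therefore expected at 110 nM, with a range of 35 nM to 350 nM, meaning an expected step of a 1.8-fold higher number from compound 2 to compound 3 (0.26 log units; within the scatter).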

Compound 3, half-maximal inhibitory concentration: 11 nM
Beside the measured number, compound 3's estimate is 10-fold (1.00 log units) above it; measured number below the stated range.
By their numbers in this assay, from the lowest: compound 3; then compound 2; then compound 1.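

In this assay, the aryl group on the double-bonded chain carbon bound to a double-bonded chain carbon and a saturated chain carbon has more influence than the first pair alone could show: a 5.5-fold lower number from compound 2 to compound 3 (0.74 log units; beyond the scatter), and across the three compounds there is a 13-fold lower number from compound 1 to compound 3 (1.10 log units; beyond the scatter). The hydrogen-bond acceptor of the 4-methoxyphenyl is not required for a low number at this position, since the 2,4-dichlorophenyl carries no hydrogen-bond acceptor and compound 3 gives the lowest number of the three. No measurement available here accounts for the size of these steps.

The three compounds do not show whether both chlorines are needed, or whether a single chlorine on the phenyl ring would give a similar number. Also open, on these data alone, is how this position responds to other groups, such as bromine, trifluoromethyl or a pyridine ring in place of the phenyl ring, and whether the order seen here would hold with an amide in place of the carboxylic acid.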